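The source may hold more compounds than are shown below. What is called first, only, known or untested is meant among the compounds shown, and "the series" means these compounds.

Compound 1 `Cc1cc(C(=O)N/N=C/c2ccc(O)cc2)c2c(C)nn(-c3ccccc3)c2n1`: > 100000 nM
Compound 2 `Cc1cc(C(=O)N/N=C/c2ccc(Br)cc2)c2c(C)nn(-c3ccccc3)c2n1`: > 100000 nM
Compound 3 `Cc1cc(C(=O)N/N=C/c2ccc(F)cc2)c2c(C)nn(-c3ccccc3)c2n1`: > 100000 nM

These three results come from an ADME assay on cells (Platelet, Homo sapiens) for inhibition, read by turbidimetry, with a stated time of 2 min (on this read-out lower numbers stand for stronger inhibition and higher numbers for weaker inhibition), and each is a limit of the assay rather than a number. Compound 3 stands only at its limit of > 100000 nM. Compound 4 `Cc1ccc(/C=N/NC(=O)c2cc(C)nc3c2c(C)nn3-c2ccccc2)cc1` differs from compound 3 in one group, 4-fluorophenyl becoming 4-methylphenyl: methyl in place of fluoro on an aromatic carbon. Three measured swaps bear on this change: a step that the two limits leave unreadable from compound 1 to compound 2, a step that the two limits leave unreadable from compound 1 to compound 3 and a step that the two limits leave unreadable from compound 2 to compound 3. None of them gives a size, and the whole series sits at one limit: the limit of > 100000 nM in this assay, at which 3 of the 3 values shown sit. No step beyond the scatter is therefore expected, and another limit is the likeliest report. The expected step is a number no higher from compound 3 to compound 4 (the limit leaves the size open). For compound 4 the estimate is 100000 nM, with an expected range of 50000 nM to 200000 nM.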

Compound 4, half-maximal inhibitory concentration: > 100000 nM
Compound 4 ended at the assay's limit (the forecaster's own chance of this, stated with the estimate: 85%); the middle value lies on the limit itself.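

Compound 4 joins compounds 1, 2 and 3 at a limit of the assay, so no step among these four compounds can be read: the limit of > 100000 nM in this assay, at which 4 of the 4 values shown sit.

What the compounds shown leave open is how strongly any of them inhibits, and whether any change to this group would bring a readable number.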